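This account rests on a few compounds, and the source may have more. Where it says the series, first, only, none or still open, it means among the compounds named here.

Measured so far in a functional assay on HeLa cells (Homo sapiens) for cytotoxicity, read by MTT assay, with a stated time of 72 h; a lower number here means a stronger inhibitor, a higher number a weaker inhibitor:
compound 1 `Cc1cc(-c2ccccc2)n(/C(N)=N/S(=O)(=O)c2cc(C)c(Cl)cc2SCc2cccc3ccccc23)n1` — 3000 nM
compound 2 `Cc1cc(S(=O)(=O)/N=C(\N)n2nccc2-c2ccccc2)c(SCc2cccc(Cl)c2)cc1Cl` — 10000 nM
compound 3 `Cc1cccc(CSc2cc(Cl)c(C)cc2S(=O)(=O)/N=C(\N)n2nc(C)cc2-c2ccccc2)c1` — 155000 nM

Compound 2 holds the middle of the three numbers in this assay: compound 1 gives a lower number, compound 3 a clearly higher one, and both gaps lie beyond the scatter.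

The unmeasured compound 4 `Cc1ccc(CSc2cc(Cl)c(C)cc2S(=O)(=O)/N=C(\N)n2nccc2-c2ccccc2)cc1` differs from compound 2 in one place: 4-methylphenyl in place of 3-chlorophenyl on a saturated chain carbon bound to a sulfur. Within the data shown here, the swap is an aryl-for-aryl exchange on the benzylic sulfide arm, and the only measured step at the same place is a 52-fold higher number from compound 1 to compound 3 (1.71 log units; beyond the scatter). That step shows that the aryl group on this arm can move the number strongly, and that a small methyl-bearing phenyl there sits at the weak end of the series. Compound 2, with 3-chlorophenyl in that spot, already sits well above compound 1. A move to 4-methylphenyl, close in kind to the 3-methylphenyl of compound 3, is therefore expected to push the number further up, though less far than the whole naphthyl-to-tolyl step, since compound 2 starts from a weaker point than compound 1.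

The expected step in this assay from compound 2 to compound 4 is a 3.0-fold higher number from compound 2 to compound 4 (0.48 log units; beyond the scatter). Compound 4 is estimated at 30000 nM, within a range from 10000 nM to 100000 nM.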

Compound 4, half-maximal inhibitory concentration: 17000 nM
The estimate for compound 4 lay 1.8-fold (0.25 log units) above the measured number; low and high end bracket the measured number.
By their numbers in this assay, from the lowest: compound 1; then compounds 2 and 4 (each within the scatter of the next); then compound 3.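

In this assay the exchange of 3-chlorophenyl for 4-methylphenyl on a saturated chain carbon bound to a sulfur gives a 1.7-fold higher number from compound 2 to compound 4 (0.23 log units; within the scatter) and leaves compound 2 and compound 4 apart by no more than repeat measurements would. This arm therefore does not answer strongly to every aryl exchange: two single-ring aryl groups of 7 heavy atoms each, one carrying chlorine and one carrying methyl, read alike on this core, whereas the large step of a 52-fold higher number from compound 1 to compound 3 (1.71 log units; beyond the scatter) takes away naphthalen-1-yl and stands on the core of compound 1. Nothing on hand gives a reason for either step.

Open, going by these compounds, is whether naphthalen-1-yl would keep its lower number on the core of compound 2, as only compound 1 carries that group here. Also open, on these data alone, is how this arm would read in this assay with an amine or a carboxylic acid on the phenyl ring, or with a longer chain in place of the saturated chain carbon.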